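The source may hold more compounds than are shown below. What is called first, only, known or untested is meant among the compounds shown, and "the series" means these compounds.

Measured so far:
Compound 1 `Cc1ccsc1-c1cc(-c2ccoc2)cc(-c2ccc(Cl)cc2)n1`: 19600 nM
Compound 2 `Clc1ccc(-c2cc(-c3ccoc3)cc(-c3ccc(Cl)s3)n2)cc1`: 19600 nM

In a functional assay on K562 cells (Homo sapiens) for cytotoxicity, read by ELISA, with a stated time of 4 days (on this read-out lower numbers stand for stronger inhibition and higher numbers for weaker inhibition), compound 1 gives 19600 nM, and compound 2 gives 19600 nM; the step of no change at the digits printed from compound 1 to compound 2 (within the scatter) leaves compound 1 level with compound 2 at the digits shown. Compound 3 `Cc1ccsc1-c1cc(-c2ccc(Cl)o2)cc(-c2ccc(Cl)cc2)n1` differs from compound 1 by 5-chlorofuran-2-yl in place of furan-3-yl on an aromatic carbon. For the measured compounds named here, the only measured step alters a different group of the shared core and stays within the scatter, so no measured step speaks to this change. Compound 3 is therefore expected to sit close to compound 1, with no change at the digits printed from compound 1 to compound 3 (within the scatter). The estimate for compound 3 is 19600 nM, ranging from 8000 nM to 45000 nM.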

Compound 3, half-maximal inhibitory concentration: 15600 nM
The estimate for compound 3 lay 1.3-fold (0.10 log units) above the measured number; measured number inside the range.
By their numbers in this assay, from the lowest: compounds 3, 1 and 2 (each within the scatter of the next).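

In this assay, the position opposite the ring nitrogen, which the earlier pair left unchanged, now has a step of its own: 5-chlorofuran-2-yl in place of furan-3-yl gives a 1.3-fold lower number from compound 1 to compound 3 (0.10 log units; within the scatter). Here, a new point of attachment on the furan and an added chlorine together keep the number within the scatter. Nothing available accounts for this result. The compounds shown cannot separate the attachment point from the chlorine, which furan-2-yl could address. They also leave open whether an amine or a carboxylic acid at this position would move the number beyond the scatter.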